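This account rests on a few compounds, and the source may have more. Where it says the series, first, only, none or still open, it means among the compounds named here.

Three compounds from one series share a bicyclic ketone core carrying a sulfonyl group that is joined to a six-membered ring holding two nitrogens, with an aromatic group attached to the far ring nitrogen. Compound 1 is `CC1(C)[C@@H]2CC[C@@]1(CS(=O)(=O)N1CCN(c3cc(C(F)(F)F)ccn3)CC1)C(=O)C2`, compound 2 is `C[C@@H]1CN(c2ccc(C(F)(F)F)cn2)[C@@H](C)CN1S(=O)(=O)C[C@]12CC[C@H](CC1=O)C2(C)C`, and compound 3 is `CC1(C)[C@@H]2CC[C@@]1(CS(=O)(=O)N1CCN(c3nc(Cl)c(C(F)(F)F)cc3Cl)CC1)C(=O)C2`. All three were tested in a functional assay on CHO-K1 cells for antagonist activity at C-X-C chemokine receptor type 3 (Homo sapiens), read by FLIPR and calcium flux; a higher number here means a weaker inhibitor, a lower number a stronger inhibitor. In this assay compound 1 gives 25100 nM, compound 2 gives 6310 nM, and compound 3 gives 316 nM. Compound 1 thus stands at the weakest end of the three: the number for compound 2 is lower by a margin beyond the usual scatter, and the number for compound 3 is lower still.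

Compound 4 is `CC1(C)[C@@H]2CC[C@@]1(CS(=O)(=O)N1CCN(c3ccc(C(F)(F)F)cc3)CC1)C(=O)C2`, not yet measured. It differs from compound 1 in one place: 4-(trifluoromethyl)phenyl in place of 4-(trifluoromethyl)pyridin-2-yl on an amine nitrogen in a ring. Among the compounds with values here, the only change is therefore the loss of the ring nitrogen from the aromatic group, with the trifluoromethyl kept. Within the data shown here, no measured pair here isolates this exact exchange, so the expectation rests on compound 1 alone. The step from compound 1 to compound 4 is expected to be small, estimated at a 2.1-fold lower number from compound 1 to compound 4 (0.32 log units; beyond the scatter), toward a somewhat lower number but perhaps not beyond the scatter. Compound 4 is expected to give about 12000 nM in this assay, most likely between 3000 nM and 40000 nM.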

Compound 4, half-maximal inhibitory concentration: > 31600 nM
Compound 4: only a limit was reported; the forecaster's own chance of this, stated with the estimate: 15%; at least 2.6-fold (0.42 log units) between middle value and limit.
By their numbers in this assay, from the lowest: compound 3; then compound 2; then compound 1. At a limit, above all of these: compound 4.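

In this assay compound 4 gives > 31600 nM, which is a limit of the assay and not a number. The step is an at least 1.2-fold higher number from compound 1 to compound 4 (0.10 log units; that floor lies within the scatter), so placing 4-(trifluoromethyl)phenyl in place of 4-(trifluoromethyl)pyridin-2-yl on this amine nitrogen brings no visible gain, although the floor of the step does not separate the two compounds. This is the first view of a carbon-only aromatic ring at this position, and the loss of the ring nitrogen, which takes away the one hydrogen-bond acceptor of the group that leaves, does not lift the compound out of the weak end of the series, but the size of the step stays unknown because the reading ends at a limit: the limit of > 31600 nM in this assay, at which 1 of the 4 values shown sits.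

The compounds shown leave open what a nitrile or a methoxy group would do in place of the trifluoromethyl on the phenyl ring. They also leave open whether an amine or a carboxylic acid on that ring would give a number that can be read inside the range of the assay.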